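This account rests on a few compounds, and the source may have more. Where it says the series, first, only, none or still open, it means among the compounds named here.

Three measured compounds share one core and differ only in the group on a sulfonyl sulfur. Compound 1 `Cn1c(=O)c(S(=O)(=O)Cc2ccc(F)cc2F)cc2cnc(Nc3ccc4[nH]ccc4c3)nc21` gives 1000 nM in a functional assay on K562 cells (Homo sapiens) for inhibition, read by trypan blue exclusion, with a stated time of 72 h; on this read-out higher numbers stand for weaker inhibition and lower numbers for stronger inhibition. Compound 2 `Cn1c(=O)c(S(=O)(=O)c2ccc([N+](=O)[O-])cc2F)cc2cnc(Nc3ccc4[nH]ccc4c3)nc21` gives 200 nM in this assay, and compound 3 `Cn1c(=O)c(S(=O)(=O)c2ccc(Cl)cc2)cc2cnc(Nc3ccc4[nH]ccc4c3)nc21` gives 100 nM, the lowest of the three numbers, reached by a 2.0-fold lower number from compound 2 to compound 3 (0.30 log units; within the scatter) and by a 10-fold lower number from compound 1 to compound 3 (1.00 log units; beyond the scatter). Compound 4 `Cn1c(=O)c(C(=O)Nc2ccc(F)cc2F)cc2cnc(Nc3ccc4[nH]ccc4c3)nc21` is not yet measured; it differs from compound 3 by (2,4-difluorophenyl)carbamoyl in place of (4-chlorophenyl)sulfonyl on an aromatic carbon. Among the compounds with values here, no measured step replaces the sulfonyl itself, so the earlier steps bear only loosely: compound 1, which carries the 2,4-difluorobenzyl, gave the highest number, and a 10-fold lower number from compound 1 to compound 3 (1.00 log units; beyond the scatter) was modest. Some loss is therefore expected, with a 3.0-fold higher number from compound 3 to compound 4 (0.48 log units; beyond the scatter), though the direction is uncertain. The estimate for compound 4 is 300 nM, expected between 60 nM and 1500 nM.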

Compound 4, half-maximal inhibitory concentration: 5000 nM
Beside the measured number, compound 4's estimate is 17-fold (1.22 log units) below it, and the stated range ends below it.
By their numbers in this assay, from the lowest: compounds 3 and 2 (each within the scatter of the next); then compound 1; then compound 4.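

The earlier compounds shown here changed only the group on the sulfonyl sulfur, whereas replacing the whole (4-chlorophenyl)sulfonyl with (2,4-difluorophenyl)carbamoyl on this aromatic carbon gives a 50-fold higher number from compound 3 to compound 4 (1.70 log units; beyond the scatter) in this assay, the largest step. This position is therefore far from indifferent to such a change, which swaps the sulfonyl for a carbamoyl and alters the ring's halogens at once. No measurement offered here explains the loss. Still open, going by these compounds, is which part of the change carries it: a (4-chlorophenyl)carbamoyl group would help separate the two.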